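Swapping the Triazole Arm for a Fluorinated Pyrazole

The compounds below may be only part of what the source reports. "The series", "measured", "known", "first", "only" and "open" are said of these compounds alone.

Compound 2 `c1cc(Cn2ccnn2)c2c(c1)C(c1ncc[nH]1)CC2` carries a 1H-1,2,3-triazol-1-yl group on a saturated chain carbon bound to an aromatic carbon of the shared core. In a functional assay on CHO cells for agonist activity at Alpha-1A adrenergic receptor (Homo sapiens), read by fluorescence and calcium flux (on this read-out lower numbers stand for an effect already at smaller amounts and higher numbers for an effect only at larger amounts of compound), compound 2 gives 90 nM. Going by the values given here, its only measured neighbour is compound 1 `COCCc1cccc2c1CCC2c1ncc[nH]1`, which carries methoxymethyl at the same place; in this assay compound 1 gives 168 nM. Among the compounds with values here, the step of a 1.9-fold lower number from compound 1 to compound 2 (0.27 log units; within the scatter) is the single step on record, and it lies within the scatter, so compound 2 gives the smaller of the two numbers without being separable from compound 1.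

Compound 3 `Fc1ccn(Cc2cccc3c2CCC3c2ncc[nH]2)n1` is not yet measured. It differs from compound 2 by 3-fluoro-1H-pyrazol-1-yl in place of 1H-1,2,3-triazol-1-yl on a saturated chain carbon bound to an aromatic carbon. Within the data shown here, no measured pair shows this exchange; the one step available, from methoxymethyl to the triazolyl group at this place, moved the number only within the scatter. From that single precedent no step beyond the scatter is expected in this assay for compound 3, in either direction, and the estimated step is no change at the digits printed from compound 2 to compound 3 (within the scatter). Compound 3 is therefore expected at 90 nM in this assay, within a range from 30 nM to 270 nM.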

Compound 3, half-maximal effective concentration: 17 nM
Compound 3: the middle estimate sits 5.3-fold (0.72 log units) above what was measured; measured number below the stated range.
By their numbers in this assay, from the lowest: compound 3; then compounds 2 and 1 (each within the scatter of the next).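

The place on a saturated chain carbon bound to an aromatic carbon had so far shown only a step within the scatter, but in this assay it now proves able to move the number: 3-fluoro-1H-pyrazol-1-yl in place of 1H-1,2,3-triazol-1-yl gives a 5.3-fold lower number from compound 2 to compound 3 (0.72 log units; beyond the scatter), a step beyond the scatter between two five-membered aromatic rings carried at the same place. Set against the open-chain methoxymethyl group, the same 3-fluoro-1H-pyrazol-1-yl group gives a 9.9-fold lower number from compound 1 to compound 3 (0.99 log units; beyond the scatter), so compound 3 stands apart from both compound 1 and compound 2, which remain within the scatter of each other. Nothing available explains why this exchange moves the number.

The exchange replaces the ring and adds the fluorine in a single step, so these compounds cannot show how much of the step belongs to the pyrazole ring and how much to the fluorine. On these data alone, it also remains open whether plain 1H-pyrazol-1-yl, 3-chloro-1H-pyrazol-1-yl or a simple amine at this place would give a number near that of compound 3.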